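The source may hold more compounds than are shown below. What is called first, only, known or untested is meant among the compounds shown, and "the series" means these compounds.

Compound 1 `O=C1O/C(=C\Cn2cc(-c3ccc(Br)cc3)nn2)C(OCc2ccccc2)=C1OCc1ccccc1` in a functional assay on MCF7 cells (Homo sapiens) for antiproliferative activity, read by MTT assay, with a stated time of 72 h (on this read-out higher numbers stand for weaker inhibition and lower numbers for stronger inhibition), gives > 100000 nM, which is a limit of the assay and not a number.
Compound 2 `CC(C)(C)OC(=O)N1CCN(C(=S)SCc2cn(C[C@H](O)[C@H]3OC(=O)C(OCc4ccccc4)=C3OCc3ccccc3)nn2)CC1` gives > 100000 nM, again a limit of the assay rather than a number.
Compound 3 `O=C1O[C@H]([C@@H](O)Cn2cc(CNS(=O)(=O)c3ccc(F)cc3)nn2)C(OCc2ccccc2)=C1OCc1ccccc1` gives 26800 nM.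

Among these three, compound 3 carries the only true number; the other two values stop at the limit of > 100000 nM in this assay, at which 2 of the 3 values shown sit, so compound 3 is the sole anchor for anything that follows. Compound 4 `O=C1O[C@H]([C@@H](O)Cn2cc(CCO)nn2)C(OCc2ccccc2)=C1OCc1ccccc1` differs from compound 3 in one place: hydroxymethyl in place of ((4-fluorophenyl)sulfonyl)amino on a saturated chain carbon bound to an aromatic carbon. Among the measured compounds shown here, no measured pair in this set shows what such a change does, so the three values themselves are all there is to lean on. With two of three compounds sitting at the limit and compound 3 itself far from strong, the expectation for compound 4 is a modest move toward weaker inhibition, estimated as a 2.2-fold higher number from compound 3 to compound 4 (0.35 log units; beyond the scatter), a step that could fall within the usual scatter or just beyond it. Compound 4 is therefore expected to give about 60000 nM, within a range from 15000 nM to 200000 nM, with a real chance that the assay reports only a limit and no number.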

Compound 4, half-maximal inhibitory concentration: 63400 nM
Beside the measured number, compound 4's estimate is 1.1-fold (0.02 log units) below it, within the range that was stated.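

In this assay, among the compounds shown here, hydroxymethyl in place of ((4-fluorophenyl)sulfonyl)amino, on a saturated chain carbon bound to an aromatic carbon, gives a 2.4-fold higher number from compound 3 to compound 4 (0.37 log units; beyond the scatter), the only step at this position that can be read. The group that leaves has 11 heavy atoms and a six-membered aromatic ring, while the group that enters has 2 heavy atoms and no ring, so this large cut goes with only a modest step, and the fluorinated aromatic ring and its sulfonyl link are not needed for this assay to return a true number. Compound 4 thus joins compound 3 as a second true number in a set where the other values are limits: the limit of > 100000 nM in this assay, at which 2 of the 4 values shown sit.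

What remains open is which part of the departing group accounts for the step, the fluorine, the aromatic ring or the sulfonyl amino link; all of them leave together in this one change. The compounds shown also cannot tell whether an amine, a carboxylic acid or a longer chain in this place would give a lower number than compound 3 or stop at the limit.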